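Shortening a Long Chain on a Shared Core

The compounds below may be only part of what the source reports. "The series", "measured", "known", "first", "only" and "open" are said of these compounds alone.

Of the compounds shown here, two built on one core have been measured in a functional assay on cells (Lymphocyte, Homo sapiens), read by trypan blue exclusion, with a stated time of 16 h, tested at 2.5 uM; on this read-out higher numbers stand for a stronger effect at the one concentration tested and lower numbers for a weaker effect. Compound 1 `CCCCCCCCCCc1nc(N(C)C)c(C)c(C)c1O` gives 79%. Compound 2 `CCCCCCCCCCCCCCCCCCCc1nc(N(C)C)c(C)c(C)c1O` gives 66% and stands as the lower of the two numbers, with compound 1 the nearer and higher one, beyond the scatter. Among the measured compounds shown here, the single measured step, a number 13 percentage points lower from compound 1 to compound 2 (beyond the scatter), came with nonyl in place of hydrogen on a saturated chain carbon, ten or more bonds along the chain from an aromatic carbon.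

Compound 3 `CCCCCCCCCCCCCCCCc1nc(N(C)C)c(C)c(C)c1O` is not yet measured. It differs from compound 2 by hydrogen in place of propyl on a saturated chain carbon, ten or more bonds along the chain from an aromatic carbon. This partly reverses the measured step, taking away a shorter piece than was added. Since a far longer addition cost only a number 13 percentage points lower from compound 1 to compound 2 (beyond the scatter), the estimated step of a number 4 percentage points higher from compound 2 to compound 3 (within the scatter) is small and upward, within the scatter. Compound 3 is therefore expected to give 70%, within a range from 60% to 80%.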

Compound 3, a percentage reported as activity, at one concentration (the size of the read-out at that concentration, not a potency): 83%
For compound 3 the middle estimate is 13 percentage points below the measured one; the whole stated range lies below it.
By their numbers in this assay, from the lowest: compound 2; then compounds 1 and 3 (each within the scatter of the next).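

Taking propyl off the chain gives a number 17 percentage points higher from compound 2 to compound 3 (beyond the scatter), so removing this short piece is enough to separate the two compounds. Putting hexyl in place of hydrogen on a saturated chain carbon gives a number 4 percentage points higher from compound 1 to compound 3 (within the scatter), which means that compound 1 and compound 3 cannot be told apart in this assay. Among these three compounds, the chain therefore takes the hexyl extension without a readable change, and only the nonyl extension brings a drop.

Still open, from the compounds shown here alone, is where between the chains of compound 3 and compound 2 the drop sets in, and whether a shorter chain, or a chain ending in an amine or a carboxylic acid, would hold the same level. Nothing available explains why the longest chain gives the lower number.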